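Inverting One Stereocentre From a Solubility Limit

This account rests on a few compounds, and the source may have more. Where it says the series, first, only, none or still open, it means among the compounds named here.

Measured in a physicochemical assay for solubility, read by HPLC, in simulated intestinal fluid, with a stated time of 16 h, at pH 6.5; a higher number here means a more soluble compound, a lower number a less soluble compound:
compound 1 `C[C@H]1C(=O)N(C)C=C(c2cn[nH]c2)c2cc([C@@H](O)CO)ccc21` gives 417 ug/mL
compound 2 `C[C@H]1C(=O)N(C)C=C(c2cnn(C)c2)c2cc([C@H](O)CO)ccc21` gives > 1000 ug/mL (a limit)

Compound 2 stands at > 1000 ug/mL in this assay and that is a limit of the assay, not a number. The next case is compound 3 `C[C@H]1C(=O)N(C)C=C(c2cnn(C)c2)c2cc([C@@H](O)CO)ccc21`, and the structural change is this: the two compounds have the same atoms and bonds and differ only in configuration as drawn: 1 of 2 stereo elements differ; a stereocentre at a saturated chain carbon is drawn S in compound 2 and R in compound 3. For the measured compounds named here, no measured pair shows what such an inversion does in this assay, so the expectation is a loose one. Going by the values given here, compound 1 gives 417 ug/mL as the only exact number available, and the lower end of the range is set with it in mind. With atoms and bonds unchanged, the expected outcome is no large change, and any real shift can be expected only downward. The estimated move is an at least 1.2-fold lower number from compound 2 to compound 3 (0.09 log units; that floor lies within the scatter) and may well stay within the scatter. For compound 3 the expected solubility is 800 ug/mL, with an estimated range of 350 ug/mL to 1500 ug/mL.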

Compound 3, solubility: > 1000 ug/mL
Compound 3 was reported as a limit; the forecaster's own chance of this, stated with the estimate: 45%; middle value at least 1.2-fold (0.09 log units) away from the limit.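

In this assay compound 3 gives > 1000 ug/mL, which is a limit of the assay and not a number. For the compounds shown here, the step between the two configurations cannot be read, because both compounds sit at that ceiling and nothing else separates them: the limit of > 1000 ug/mL in this assay, at which 2 of the 3 values shown sit. Compound 3 does, however, supply the first comparison in one place with the exact value of compound 1: with the configuration unchanged, methyl in place of hydrogen on an aromatic nitrogen comes with an at least 2.3-fold higher number from compound 1 to compound 3 (0.37 log units; beyond the scatter).

On these data alone, how far apart the two configurations lie in solubility remains unknown, as does whether either would differ under a higher ceiling. Also open, as far as these compounds go, is what a longer chain such as ethyl, or a chain ending in an amine, would give on that aromatic nitrogen in place of methyl.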